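Working notes: the step from compound 3 to compound 4

A few compounds are considered here, and "the series" means these few. Any claim that something is new, unique, unknown or untested is made for them only; others in the source may bear on it.

Measured so far in an assay on HEK293 cells for inhibition of Fatty-acid amide hydrolase 1 (Homo sapiens), read by fluorescence; on this read-out higher numbers stand for weaker inhibition and lower numbers for stronger inhibition:
- compound 1, `c1cc2cc(-c3ccc4oc(NC5CCCCC5)nc4c3)cnc2[nH]1`: > 1000 nM
- compound 2, `CCn1ccc2cc(-c3ccc4oc(NC5CCCCC5)nc4c3)ccc21`: 207 nM
- compound 3, `Cn1ccc2cc(-c3ccc4oc(Nc5ccccc5)nc4c3)ccc21`: 48 nM

The value given for compound 1 is a limit of this assay, not a number; it sits at the limit of > 1000 nM in this assay, at which 1 of the 3 values shown sits. Among the two numbers that are known, compound 3 has the lower one; compound 2 stands at a number higher by a margin beyond the scatter. Compound 3 is thus the reference point of the series as it stands.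

Compound 4, `CNc1nc2cc(-c3ccc4c(ccn4C)c3)ccc2o1`, has not yet been measured. It differs from compound 3 in one place: methyl in place of phenyl on a nitrogen on an aromatic ring. In other words, the anilino group on the shared core becomes a methylamino group, and the six-membered aromatic ring of carbon only is gone.

Among the measured compounds shown here, no measured pair isolates this change, so the direction can only be set by expectation. Losing the phenyl removes most of the bulk at that nitrogen, and within this series the compounds that carry a smaller or different ring at the same nitrogen do not reach the number of compound 3. The expectation is therefore a rise, beyond the scatter, with considerable uncertainty: the step from compound 3 to compound 4 is estimated at a 6.3-fold higher number from compound 3 to compound 4 (0.80 log units; beyond the scatter). Compound 4 is expected to give about 300 nM in this assay, with a plausible range from 60 nM to 1500 nM.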

Compound 4, half-maximal inhibitory concentration: > 1000 nM
Compound 4: no number, only a limit; the forecaster's own chance of this, stated with the estimate: 15%; middle value at least 3.3-fold (0.52 log units) from the limit.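

In this assay, among the compounds shown here, the change from anilino to methylamino gives the first single-place comparison, and the phenyl on this nitrogen proves to matter: the step is an at least 20-fold higher number from compound 3 to compound 4 (1.31 log units; beyond the scatter), large and beyond the scatter. Compound 4 gives > 1000 nM, which is a limit of the assay and not a number, so this step marks only the smallest size the change can have. With one six-membered aromatic ring of carbon only replaced by methyl, the measurable inhibition of compound 3 is lost at this position, and the series now has a second compound at the limit: the limit of > 1000 nM in this assay, at which 2 of the 4 values shown sit.

As far as these compounds go, what remains open is whether the aromatic ring itself or simply a larger group on this nitrogen is what compound 3 needs, since compound 2 carries a different ring here but also differs from compound 3 elsewhere. A benzyl group, a pyridyl ring or a longer chain such as n-butyl on this nitrogen, each set on the core of compound 3, would separate these readings.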